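Adding a Second Bromo to the Hydrazone Aryl Ring

A few compounds are considered here, and "the series" means these few. Any claim that something is new, unique, unknown or untested is made for them only; others in the source may bear on it.

Compound 3 `COc1cc(/C=N/Nc2nc(-c3ccc(F)c(F)c3)cs2)cc(Br)c1OC` gives 21100 nM in a functional assay on A549 cells (Homo sapiens) for inhibition, read by MTT assay, with a stated time of 48 h (on this read-out lower numbers stand for stronger inhibition and higher numbers for weaker inhibition), the second highest of the three numbers measured; compound 1 `COc1cc(/C=N/Nc2nc(-c3ccccc3)cs2)c(Br)c(Br)c1OC` gives 15300 nM, within the scatter of compound 3, while compound 2 `COc1ccccc1-c1csc(N/N=C/c2cc(OC)c(OC)c(Br)c2Br)n1` gives 85100 nM, beyond it. Compound 4 `COc1cc(/C=N/Nc2nc(-c3ccc(F)c(F)c3)cs2)c(Br)c(Br)c1OC` differs from compound 3 by bromo in place of hydrogen on an aromatic carbon, on an aromatic carbon ortho to a bromo group. Among the compounds with values here, the one measured step, a 5.6-fold higher number from compound 1 to compound 2 (0.75 log units; beyond the scatter), concerns a methoxy on the other ring and does not bear on this change; compounds 1 and 3 differ in two places at once, so their values alone say nothing clean about a second bromo. He therefore expects a 1.2-fold lower number from compound 3 to compound 4 (0.07 log units; within the scatter), no step beyond the scatter, and estimates compound 4 at 18000 nM, between 7000 nM and 50000 nM.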

Compound 4, half-maximal inhibitory concentration: 8380 nM
Beside the measured number, compound 4's estimate is 2.1-fold (0.33 log units) above it; low and high end bracket the measured number.
By their numbers in this assay, from the lowest: compounds 4, 1 and 3 (each within the scatter of the next, the first and the last beyond it); then compound 2.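

In this assay, within the data shown here, the step of a 2.5-fold lower number from compound 3 to compound 4 (0.40 log units; beyond the scatter) shows that bromo in place of hydrogen on this aromatic carbon, ortho to a bromo group, changes the number beyond the scatter, which no earlier pair could show. With this bromo pair held constant, the aryl group matters unevenly: a 10-fold lower number from compound 2 to compound 4 (1.01 log units; beyond the scatter) is a large step, whereas a 1.8-fold lower number from compound 1 to compound 4 (0.26 log units; within the scatter) stays within the scatter. Nothing available explains the effect of the added bromo.

On these data alone, whether a chloro, a methyl or a nitrile on this carbon would act like bromo remains open. So does whether the added bromo gives a similar step with phenyl in place of 3,4-difluorophenyl.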